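The source may hold more compounds than are shown below. What is called first, only, known or untested is meant among the compounds shown, and "the series" means these compounds.

Notes on the series. In a functional assay on T47D cells (Homo sapiens) for inhibition, read by sulforhodamine B assay, with a stated time of 48 h (on this read-out higher numbers stand for weaker inhibition of growth and lower numbers for stronger inhibition of growth), compound 1 `COc1ccc(-c2[nH]c3ccccc3c2/C=C(\C#N)S(=O)(=O)c2ccccc2)cc1` gives 533 nM, compound 2 `O=C(/C(=C\c1c(-c2ccccc2)[nH]c2ccccc12)S(=O)(=O)c1ccccc1)c1ccccc1` gives 3400 nM, and compound 3 `N#C/C(=C\c1c(-c2ccccc2)[nH]c2ccccc12)S(=O)(=O)c1ccccc1` gives 3800 nM. Compound 3 holds the highest number of the three: the step of a 1.1-fold higher number from compound 2 to compound 3 (0.05 log units; within the scatter) stays within the scatter, while the step of a 7.1-fold higher number from compound 1 to compound 3 (0.85 log units; beyond the scatter) is a modest step beyond it.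

The next step goes from compound 3 to compound 4 `N#C/C(=C\c1c(-c2ccccc2)[nH]c2ccccc12)C(=O)c1ccccc1`: benzoyl in place of phenylsulfonyl on a double-bonded chain carbon bound to a double-bonded chain carbon and a triple-bonded carbon. Among the measured compounds shown here, no measured pair exchanges phenylsulfonyl for benzoyl. The step that comes closest is a 1.1-fold higher number from compound 2 to compound 3 (0.05 log units; within the scatter), which exchanged the other group on the same carbon and left this assay unmoved; compound 2 and compound 4 both carry a benzoyl on the chain, paired there with a different partner. That gives no reason to expect a step beyond the scatter, but the lack of a direct comparison widens the range.

Compound 4 is therefore expected in this assay near 3500 nM, in a range of 1200 nM to 10000 nM, an estimated step of a 1.1-fold lower number from compound 3 to compound 4 (0.04 log units; within the scatter).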

Compound 4, concentration for 50% growth inhibition: 5300 nM
Beside the measured number, compound 4's estimate is 1.5-fold (0.18 log units) below it; the range from low to high includes it.
By their numbers in this assay, from the lowest: compound 1; then compounds 2, 3 and 4 (each within the scatter of the next).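

Among the compounds shown here, with the nitrile kept on the chain carbon, benzoyl can stand in place of phenylsulfonyl without leaving the scatter: in this assay the exchange gives a 1.4-fold higher number from compound 3 to compound 4 (0.14 log units; within the scatter) and is the first direct reading of this change. Together with a 1.1-fold higher number from compound 2 to compound 3 (0.05 log units; within the scatter), it extends the flat picture on this carbon to a second exchange, so the only step beyond the scatter remains the one at the aromatic carbon, a 7.1-fold higher number from compound 1 to compound 3 (0.85 log units; beyond the scatter). No measurement in hand accounts for the small size of this step.

On these data alone, it remains open whether a methoxy on the aromatic carbon would bring the same gain to compound 4 as it does in the phenylsulfonyl and nitrile pairing of compound 1. Also open, as far as these compounds go, is whether an amine or a carboxylic acid on the chain carbon would stay as flat as benzoyl and phenylsulfonyl.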